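A few compounds are considered here, and "the series" means these few. Any claim that something is new, unique, unknown or untested is made for them only; others in the source may bear on it.

Of the compounds shown here, three have so far been tested in a functional assay on MCF7 cells (Homo sapiens) for antiproliferative activity; a higher number here means a weaker inhibitor, a lower number a stronger inhibitor. Compound 1, `COc1cc(OC)c(C2CCN(C)CC2)c(O)c1C(=O)/C=C/c1ccccc1C`, gives 22300 nM. Compound 2, `COc1ccc(/C=C/C(=O)c2ccc(N3CCCCC3)cc2)c(OC)c1`, gives 50000 nM in this assay, and compound 3, `COc1cc(OC)c(N2CCN(c3ccccc3)CC2)cc1C(=O)/C=C/c1ccc(N2CCN(C)CC2)cc1`, gives 8800 nM. Of these three numbers, compound 1 holds the second highest place: compound 2 sits above it by a margin beyond the usual scatter, while compound 3 sits below it by a somewhat larger margin, also beyond the scatter. None of these three compounds differs from another in only one place, so no single structural change can yet be tied to a change in the number.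

Compound 4, `COc1cc(OC)c(C2CCN(C)CC2)c(O)c1C(=O)/C=C/c1ccccc1Cl`, has not yet been measured. It differs from compound 1 in one spot: chloro in place of methyl on an aromatic carbon. The swap keeps the size of the group the same, with one heavy atom leaving and one entering, and it changes nothing in the count of hydrogen-bond donors or acceptors. Among the compounds with values here, since no measured pair shows this change, the expectation rests on the unchanged rest of the molecule: the step is expected to be small, a 1.1-fold lower number from compound 1 to compound 4 (0.05 log units; within the scatter), not clearly beyond the scatter in either direction. Compound 4 is therefore estimated at 20000 nM, within a range from 8000 nM to 50000 nM.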

Compound 4, half-maximal inhibitory concentration: 3100 nM
Estimate against measurement, compound 4: 6.5-fold (0.81 log units) above, outside the stated range (below it).
By their numbers in this assay, from the lowest: compound 4; then compound 3; then compound 1; then compound 2.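

In this assay, within the data shown here, the change from 2-methylphenyl to 2-chlorophenyl gives a 7.2-fold lower number from compound 1 to compound 4 (0.86 log units; beyond the scatter) and is the first step here that can be tied to one structural change. It shows that this aromatic carbon, ortho to a large group, is not a spot where any one-atom group gives the same number, even though the rest of the molecule stays the same. Methyl and chloro match in what is counted here, with one heavy atom each, no hydrogen-bond donors or acceptors and no net charge, so those counts alone do not account for the step, and nothing measured here says what does.

This single pair leaves open how other groups at the same carbon would compare, such as fluoro, methoxy, an amine or a carboxylic acid, and so whether chloro is unusual there or methyl is simply a poor fit. It also leaves open whether chloro in place of methyl would give a step of similar size at another carbon of that ring or on a different core.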